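Second methoxy on the benzyl arm: an untested direction

The source may hold more compounds than are shown below. What is called first, only, known or untested is meant among the compounds shown, and "the series" means these compounds.

Of the compounds shown here, three with a common core have been tested in a functional assay on MCF7 cells (Homo sapiens) for antiproliferative activity, read by sulforhodamine B assay, with a stated time of 48 h; on this read-out lower numbers stand for stronger inhibition of growth and higher numbers for weaker inhibition of growth. Compound 1 `COc1ccc(-c2nn(-c3ccccc3)cc2C(=O)NCc2cn(Cc3ccc(F)cc3)nn2)cc1` gives 460 nM. Compound 2 `COc1ccc(-c2nn(-c3ccccc3)cc2C(=O)NCc2cn(Cc3ccc(Cl)cc3)nn2)cc1` gives 2900 nM. Compound 3 `COc1ccc(Cn2cc(CNC(=O)c3cn(-c4ccccc4)nc3-c3ccc(OC)cc3)nn2)cc1` gives 22900 nM, the highest of the three numbers and therefore the weakest growth inhibition among them. The three differ only in the group on the benzyl arm: swapping gave a 6.3-fold higher number from compound 1 to compound 2 (0.80 log units; beyond the scatter), a 50-fold higher number from compound 1 to compound 3 (1.70 log units; beyond the scatter) and a 7.9-fold higher number from compound 2 to compound 3 (0.90 log units; beyond the scatter), so each exchange at this spot shifted the number by more than the scatter.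

Compound 4 `COc1ccc(-c2nn(-c3ccccc3)cc2C(=O)NCc2cn(Cc3cc(OC)cc(OC)c3)nn2)cc1` has not been measured. It differs from compound 3 by 3,5-dimethoxyphenyl in place of 4-methoxyphenyl on a saturated chain carbon bound to an aromatic nitrogen. Among the measured compounds shown here, none of the measured steps covers this kind of change: each of them replaced one group by another single group, whereas here a methoxy is kept and a second one is added in a different arrangement. For the measured compounds named here, the only guidance is that changes on this arm have moved the numbers in this assay by modest to large amounts in every case seen.

Going by the values given here, with no step bearing directly on the change, compound 4 is expected to stay close to compound 3, with the step of a 1.1-fold lower number from compound 3 to compound 4 (0.06 log units; within the scatter) carrying wide uncertainty; the estimate for compound 4 in this assay is 20000 nM, within a range of 4000 nM to 80000 nM.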

Compound 4, concentration for 50% growth inhibition: 700 nM
Beside the measured number, compound 4's estimate is 29-fold (1.46 log units) above it, and the stated range ends above it.
By their numbers in this assay, from the lowest: compounds 1 and 4 (each within the scatter of the next); then compound 2; then compound 3.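

In this assay, the benzyl arm turns out to be far more sensitive than a one-group swap suggested: going from 4-methoxybenzyl to 3,5-dimethoxybenzyl gives a 33-fold lower number from compound 3 to compound 4 (1.51 log units; beyond the scatter), so an arm carrying methoxy groups can reach the low end of the numbers, which compound 3 alone gave no sign of. The same arm also compares well with the chloro-bearing arm, with a 4.1-fold lower number from compound 2 to compound 4 (0.62 log units; beyond the scatter), and it matches the fluoro-bearing arm within the scatter, with a 1.5-fold higher number from compound 1 to compound 4 (0.18 log units; within the scatter), so a halogen on this arm is not required for a number at this level. No measurement on hand accounts for the large drop seen with this change.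

The change to compound 4 alters both the number of methoxy groups and where they sit, and the compounds shown cannot separate these two contributions. Also open, from the compounds shown here alone, is how this assay would respond to a plain benzyl with no substituent, to a longer chain such as phenethyl, or to an arm bearing an amine or a carboxylic acid.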